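Moving the hydroxyl on the anilino ring: compound 3

A few compounds are considered here, and "the series" means these few. Any claim that something is new, unique, unknown or untested is made for them only; others in the source may bear on it.

Compound 1 `Fc1cccc(-c2nc(Nc3ccccc3Br)c3cc(F)ccc3n2)c1` gives in a functional assay on HT29-AK cells (Homo sapiens) for cytotoxicity, read by MTT assay, with a stated time of 48 h (on this read-out higher numbers stand for weaker inhibition and lower numbers for stronger inhibition), only a limit of the assay, > 50000 nM.
Compound 2 `Oc1cccc(Nc2nc(-c3cccc(F)c3)nc3ccc(F)cc23)c1` gives in this assay likewise only a limit of the assay, > 50000 nM.

Among the measured compounds shown here, compound 2 therefore stands at the limit, not at a measured number, and so does its only neighbour in the set. The step from compound 1 to compound 2, in which 3-hydroxyphenyl replaces 2-bromophenyl on a nitrogen on an aromatic ring, reads as a step that the two limits leave unreadable from compound 1 to compound 2: both ends sit at the limit, as the limit of > 50000 nM in this assay, at which 2 of the 2 values shown sit, records, so its size cannot be read.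

Compound 3 `Oc1ccccc1Nc1nc(-c2cccc(F)c2)nc2ccc(F)cc12` differs from compound 2 by 2-hydroxyphenyl in place of 3-hydroxyphenyl on a nitrogen on an aromatic ring. The same atoms are kept and only the position of the hydroxyl on the ring changes. For the measured compounds named here, no measured step in this set reports a number for a change of this kind, and the one step that touches the anilino ring is unreadable. The expectation for compound 3 therefore rests on compound 2 sitting at the limit: no change beyond the scatter is expected, and the step from compound 2 to compound 3 is estimated as a number no higher from compound 2 to compound 3 (the limit leaves the size open). Compound 3 is expected to give about 50000 nM, within a range from 15000 nM to 200000 nM, most probably reported again only as a limit.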

Compound 3, half-maximal inhibitory concentration: > 50000 nM
Compound 3: only a limit was reported; the forecaster's own chance of this, stated with the estimate: 75%; the middle value sits exactly at the limit.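

Compound 3 gives only a limit of the assay in this assay, as do compound 1 and compound 2, so none of the steps among the three can be read: the limit of > 50000 nM in this assay, at which 3 of the 3 values shown sit. The compounds shown leave open how 2-bromophenyl, 3-hydroxyphenyl and 2-hydroxyphenyl on the nitrogen would rank against one another in a measured number.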